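Acyl in place of sulfonyl on the amine nitrogen

The source may report more compounds than this note shows. Statements on the series, on what has been measured and on what is new or still open speak of the compounds shown alone.

In an assay on a protein complex for inhibition of integrin alpha-5/beta-1 (Homo sapiens), read by ELISA (on this read-out lower numbers stand for stronger inhibition and higher numbers for weaker inhibition), compound 2 `Cc1cc(C)c(S(=O)(=O)N[C@@H](CNC(=O)CO[C@@H]2C[C@@H](CNc3ccccn3)N(C(=O)CC(C)(C)C)C2)C(=O)O)c(C)c1` gives 6 nM, the higher of the two numbers recorded; compound 1 `COc1ccnc(NC[C@@H]2C[C@@H](OCC(=O)NC[C@H](NC(=O)C3(C)CCCCC3)C(=O)O)CN2C(=O)CC(C)(C)C)c1` gives 0.55 nM in this assay, a gap beyond the scatter. Compound 3 `CC(C)(C)CC(=O)N1C[C@H](OCC(=O)NC[C@H](NC(=O)C2(C)CCCCC2)C(=O)O)C[C@H]1CNc1ccccn1` carries the change ((1-methylcyclohexyl)carbonyl in place of (2,4,6-trimethylphenyl)sulfonyl on an amine nitrogen), the same (1-methylcyclohexyl)carbonyl that stands in compound 1. Among the compounds with values here, since no measured pair isolates this change, the expectation rests on compound 1 giving 0.55 nM, and the expected step is a 6.0-fold lower number from compound 2 to compound 3 (0.78 log units; beyond the scatter), a lowering beyond the scatter. For compound 3 the estimate in this assay is 1 nM, with a range from 0.3 nM to 4 nM.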

Compound 3, half-maximal inhibitory concentration: 1.4 nM
Compound 3: the middle estimate sits 1.4-fold (0.15 log units) below what was measured, and the stated range covers the measured number.
By their numbers in this assay, from the lowest: compound 1; then compound 3; then compound 2.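

On the amine nitrogen, the step in this assay now isolates the exchange of (2,4,6-trimethylphenyl)sulfonyl for (1-methylcyclohexyl)carbonyl (a 4.3-fold lower number from compound 2 to compound 3 (0.63 log units; beyond the scatter)), a modest gain for the acyl group. Hydrogen in place of methoxy on an aromatic carbon is also isolated (a 2.5-fold higher number from compound 1 to compound 3 (0.41 log units; beyond the scatter)), so the gap between compound 1 and compound 2 reflects two separate changes. Nothing available explains either step. As far as these compounds go, it remains open whether an acetyl or a methanesulfonyl group would keep the number low on this nitrogen, and whether an ethoxy group or a fluorine atom on that aromatic carbon would match methoxy.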